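One Stereocentre Flipped, Same Atoms Kept

The source may report more compounds than this note shows. Statements on the series, on what has been measured and on what is new or still open speak of the compounds shown alone.

Compound 1, `O=C(NO)c1cccc(-c2cn([C@H]3C[C@@H](CO)N(CCCc4ccccc4)C3)nn2)c1`: < 10%
Compound 2, `O=C(NO)c1ccc(-c2cn([C@H]3C[C@H](CO)N(CCCc4ccccc4)C3)nn2)cc1`: 18%

Among the compounds with values here, in an assay on Sf9 cells for inhibition of histone deacetylase 11 (Homo sapiens), read by fluorescence, tested at 0.5 uM (a higher number here means more inhibition at the concentration tested (going by the name of the read-out), a lower number less inhibition), compound 2 gives 18%, the only number here. For compound 1 the assay reports a limit, < 10%, and not a number (the limit of < 10% in this assay, at which 1 of the 2 values shown sits).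

Compound 3, `O=C(NO)c1ccc(-c2cn([C@H]3C[C@@H](CO)N(CCCc4ccccc4)C3)nn2)cc1`, is to be measured. It differs from compound 2 as follows: the two compounds have the same atoms and bonds and differ only in configuration as drawn: 1 of 2 stereo elements differ; a stereocentre at a saturated ring carbon is drawn R in compound 2 and S in compound 3. Within the data shown here, no measured pair differing only at a stereocentre exists, so no step can be read from the data. A change beyond the usual scatter is not expected in either direction. Compound 3 is expected to give 15%, between 5% and 30%. The expected step of a number 3 percentage points lower from compound 2 to compound 3 (within the scatter) is estimated to lie within the scatter.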

Compound 3, a percentage reported as inhibition, at one concentration (the size of the read-out at that concentration, not a potency): < 10%
Compound 3: only a limit was reported (the forecaster's own chance of this, stated with the estimate: 25%); middle value at least 5 percentage points from the limit.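

Within the data shown here, this is the first pair that differs only at a stereocentre, and in this assay the flip gives a number at least 8 percentage points lower from compound 2 to compound 3 (that floor lies within the scatter). On these data alone, the value of compound 3 is a limit and not a number: the step has a floor only, and its true size stays unknown. The step from compound 1 to compound 3, 4-(hydroxycarbamoyl)phenyl in place of 3-(hydroxycarbamoyl)phenyl, cannot be read: both values are limits. Still open, as far as these compounds go, is what flipping the other stereocentre does, and whether an amine or a carboxylic acid in place of the hydroxymethyl group changes the reading.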